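The source may hold more compounds than are shown below. What is called first, only, known or untested is meant among the compounds shown, and "the series" means these compounds.

Series of bridged diaryl compounds on a shared core, run in a functional assay on MKN-45 cells (Homo sapiens) for antiproliferative activity, read by MTT assay, with a stated time of 72 h; on this read-out higher numbers stand for weaker inhibition and lower numbers for stronger inhibition. Compound 1 `COc1cc(CCc2ccc(F)cc2)cc(OC)c1O` gives 10700 nM in this assay. Compound 2 `COc1cc(CCc2cccc(F)c2)cc(OC)c1O` gives 2970 nM, and compound 3 `COc1cc(CCc2ccccc2Cl)cc(OC)c1O` gives 24500 nM. Among these three numbers compound 1 stands second highest: compound 3 lies nearest, with a number beyond the scatter above it, and compound 2 lies furthest, with a number beyond the scatter below it.

Compound 4 `COc1cc(CCc2ccc([N+](=O)[O-])cc2)cc(OC)c1O` has not yet been measured. It differs from compound 1 in one place: nitro in place of fluoro on an aromatic carbon. Among the compounds with values here, no pair of measured compounds shows this change, so the direction of the step cannot be read from any earlier pair. Within the data shown here, the only guidance is that the three measured compounds, which vary only at the pendant ring, spread over a range that reaches beyond the scatter on both sides of compound 1, so a move in either direction is possible and a wide range is appropriate.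

For compound 4 the expected step is a 1.2-fold lower number from compound 1 to compound 4 (0.08 log units; within the scatter), that is, nothing beyond the scatter. Compound 4 is therefore estimated at 9000 nM in this assay, with a range from 3000 nM to 30000 nM.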

Compound 4, half-maximal inhibitory concentration: 15400 nM
The estimate for compound 4 lay 1.7-fold (0.23 log units) below the measured number; the measured number falls inside the stated range.
By their numbers in this assay, from the lowest: compound 2; then compounds 1, 4 and 3 (each within the scatter of the next, the first and the last beyond it).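

In this assay, within the data shown here, the exchange of fluoro for nitro on the aromatic carbon para to a large group gives a 1.4-fold higher number from compound 1 to compound 4 (0.16 log units; within the scatter) and is the first single-place step that can be read. At this position, 3 heavy atoms with 2 hydrogen-bond acceptors thus replace a single fluorine without a change beyond the scatter, so this one exchange gives no sign that the read-out depends on which of the two groups is present. No measurement at hand accounts for this lack of separation between the two groups.

On these data alone, it remains open whether the same position tolerates groups of a different kind, such as an amine, a carboxylic acid or a longer chain, or whether one of these would move the number beyond the scatter in either direction. As far as these compounds go, it also remains open whether nitro on another aromatic carbon of the pendant ring would give a similar result, and any such comparison would need a pair of compounds that differ in only one place.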